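The source may hold more compounds than are shown below. What is called first, only, known or untested is meant among the compounds shown, and "the series" means these compounds.

Among the compounds with values here, in a functional assay on KB cells (Homo sapiens) for antiproliferative activity, read by sulforhodamine B assay, with a stated time of 72 h (on this read-out lower numbers stand for stronger inhibition and higher numbers for weaker inhibition), only three compounds have results so far. Compound 1 `COc1cc2occ(-c3csc4ccccc34)c(=O)c2cc1OC` gives > 10000 nM, which is a limit of the assay and not a number. Compound 2 `O=c1c(-c2csc3ccccc23)coc2ccccc12` gives > 10000 nM, which is also a limit. The record is therefore marked by the limit of > 10000 nM in this assay, at which 2 of the 3 values shown sit.

Within the data shown here, compound 3 `O=C(/C=C/c1csc2ccccc12)c1ccccc1O` gives 6200 nM, the only true number in the set, so it is the one firm reference point. Its place relative to the other two cannot be fixed any more exactly than that.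

Compound 4 `CCOc1ccc(O)c(C(=O)/C=C/c2csc3ccccc23)c1` has not yet been measured. It differs from compound 3 by a single change, ethoxy in place of hydrogen on an aromatic carbon, para to a hydroxy group.

Among the measured compounds shown here, no measured pair of compounds shows what such a change does, so the expectation rests on the value of compound 3 at 6200 nM and must stay broad. A small shift toward stronger inhibition in this assay seems the likeliest outcome, and it may not clearly exceed the usual scatter. The expected step is a 1.6-fold lower number from compound 3 to compound 4 (0.19 log units; within the scatter). For compound 4, the estimated value is 4000 nM, with an expected range from 1200 nM to 10000 nM.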

Compound 4, half-maximal inhibitory concentration: 5800 nM
For compound 4 the middle estimate is 1.5-fold (0.16 log units) below the measured one; the measured number falls inside the stated range.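

In this assay, the record now holds its first pair of compounds that differ in one place, with ethoxy in place of hydrogen on an aromatic carbon, para to a hydroxy group, and the change reads as a 1.1-fold lower number from compound 3 to compound 4 (0.03 log units; within the scatter). So at this position on the six-membered aromatic ring, adding ethoxy, a group of 3 heavy atoms, leaves the read-out indistinguishable from that of the parent compound, which could not be known from any single compound alone. Compound 1 and compound 2 offer no such comparison, as each gives only a limit of the assay and not a number: the limit of > 10000 nM in this assay, at which 2 of the 4 values shown sit.

A single replacement at a single position cannot show whether this flat result would hold for other groups there, such as an amine, a carboxylic acid or a chain longer than ethoxy. The compounds shown also leave open whether ethoxy would behave the same way on another carbon of this ring, and whether the hydroxy group itself matters, since it stays unchanged across compound 3 and compound 4.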